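Losing the hydroxy-bearing aryl group in compound 3

The compounds below may be only part of what the source reports. "The series", "measured", "known", "first", "only" and "open" are said of these compounds alone.

Measured in a functional assay on SK-MEL-2 cells (Homo sapiens) for inhibition, read by sulforhodamine B assay, with a stated time of 48 h; on this read-out lower numbers stand for stronger inhibition of growth and higher numbers for weaker inhibition of growth:
- Compound 1 `Cc1ccc(C2=NN(c3ccc(S(C)(=O)=O)cc3)C(=O)CC2)cc1`: > 100000 nM
- Compound 2 `Cc1cc(O)ccc1C1=NN(c2ccc(S(C)(=O)=O)cc2)C(=O)CC1`: 32800 nM

The value of compound 1 is a limit of the assay. Among the measured compounds shown here, compound 2, at 32800 nM, holds the only actual number so far. In compound 3 `CCc1ccc(C2=NN(c3ccc(S(C)(=O)=O)cc3)C(=O)CC2)cc1`, 4-ethylphenyl takes the place of 4-hydroxy-2-methylphenyl on a carbon with a double bond to nitrogen (4-ethylphenyl in place of 4-hydroxy-2-methylphenyl on a carbon with a double bond to nitrogen). For the measured compounds named here, the one measured step that bears on this is an at least 3.0-fold lower number from compound 1 to compound 2 (0.48 log units; beyond the scatter), which brought in the group that now leaves. A reversal of similar size is therefore expected, toward weaker inhibition of growth, as a 2.4-fold higher number from compound 2 to compound 3 (0.39 log units; beyond the scatter). For compound 3 the estimated value is 80000 nM, with an expected range from 30000 nM to 100000 nM.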

Compound 3, concentration for total growth inhibition: > 100000 nM
Compound 3 was reported as a limit; the forecaster's own chance of this, stated with the estimate: 60%; at least 1.2-fold (0.09 log units) between middle value and limit.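

In this assay, 4-ethylphenyl in place of 4-hydroxy-2-methylphenyl gives an at least 3.0-fold higher number from compound 2 to compound 3 (0.48 log units; beyond the scatter), so at this carbon with a double bond to nitrogen, the ethyl-bearing aryl group does not keep the growth inhibition seen with the hydroxy-bearing one. Going from methyl to ethyl on the aryl group brings no number into the assay's range. The step from compound 1 to compound 3 cannot be read, and this step's size is bounded by the same limit: the limit of > 100000 nM in this assay, at which 2 of the 3 values shown sit. As far as these compounds go, it remains open whether the hydroxy group or the ring methyl of compound 2 carries the gain, and whether an amine or a carboxylic acid on this aryl ring would keep it.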